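The compounds below may be only part of what the source reports. "The series", "measured", "known", "first", "only" and "open" are said of these compounds alone.

Compound 1 `CCc1ccc(-c2nc(N)c3cc(Cc4ccccc4)sc3n2)o1`: 223 nM
Compound 2 `Nc1nc(-c2ncco2)nc2sc(Cc3ccccc3)cc12`: 310 nM

In a functional assay on CHO-K1 cells for antagonist activity at adenosine receptor A1 (Homo sapiens), read by a beta-galactosidase reporter and cAMP accumulation, with stated times of 15 min and 6 h (a higher number here means a weaker inhibitor, a lower number a stronger inhibitor), compound 2 gives 310 nM, the higher of the two numbers, with compound 1 close to it at 223 nM. Compound 3 `Nc1nc(-c2cnco2)nc2sc(Cc3ccccc3)cc12` differs from compound 2 by 1,3-oxazol-5-yl in place of 1,3-oxazol-2-yl on an aromatic carbon. Among the measured compounds shown here, the only measured step that bears on this aromatic carbon is a 1.4-fold higher number from compound 1 to compound 2 (0.14 log units; within the scatter), where exchanging one five-membered ring for another changed little. Moving the point of attachment within the same ring is therefore expected to shift the number by no more than a 1.3-fold higher number from compound 2 to compound 3 (0.11 log units; within the scatter), in no firm direction. Compound 3 is estimated at 400 nM, between 150 nM and 1200 nM.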

Compound 3, inhibition constant: 106 nM
The estimate for compound 3 lay 3.8-fold (0.58 log units) above the measured number, and the stated range ends above it.
By their numbers in this assay, from the lowest: compound 3; then compounds 1 and 2 (each within the scatter of the next).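

In this assay, this aromatic carbon proved sensitive to the point of attachment alone: with the same atoms joined differently, 1,3-oxazol-5-yl in place of 1,3-oxazol-2-yl gave a 2.9-fold lower number from compound 2 to compound 3 (0.47 log units; beyond the scatter). The 1,3-oxazol-5-yl group also gave a stronger inhibitor than 5-ethylfuran-2-yl, with a 2.1-fold lower number from compound 1 to compound 3 (0.32 log units; beyond the scatter). No available data account for the difference between the two attachments.

Going by these compounds, it remains open whether a thiazole ring attached at the same place would match the 1,3-oxazol-5-yl group, and whether a methyl group on that ring would keep this gain.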